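The source may hold more compounds than are shown below. What is called first, only, known or untested is meant among the compounds shown, and "the series" means these compounds.

Three compounds sharing one core were examined in a functional assay on the whole organism (stomach) with Rattus norvegicus as the target; on this read-out lower numbers stand for an effect already at smaller amounts and higher numbers for an effect only at larger amounts of compound. Compound 1 `C/N=C(/NC#N)NCCCCCn1nc(-c2ccccc2)c(C)cc1=O` reaches only a limit of the assay, > 100 mg/kg. Compound 2 `CC/N=C(/NC#N)NCCCCn1nc(-c2ccccc2)c(C)cc1=O` likewise stops at a limit, > 100 mg/kg. Among the compounds with values here, compound 3 `CC/N=C(/NC#N)NCCCCn1nc(-c2ccccc2)cc(C)c1=O` is the one that yields a number, 100 mg/kg. Compound 1 differs from compound 2 by a group of 8 heavy atoms (4 carbon, 4 nitrogen; no ring) in place of a group of 8 heavy atoms (4 carbon, 4 nitrogen; no ring), on a saturated chain carbon, four bonds along the chain from an aromatic nitrogen, yet the step that the two limits leave unreadable from compound 2 to compound 1 stays unreadable because of the limit of > 100 mg/kg in this assay, at which 2 of the 3 values shown sit. The difference between the cores of compound 2 and compound 3 is not broken down here.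

Compound 4 `C/N=C(/NC#N)NCCCCCn1nc(-c2ccccc2)cc(C)c1=O` has not been measured; it differs from compound 3 by a group of 8 heavy atoms (4 carbon, 4 nitrogen; no ring) in place of a group of 8 heavy atoms (4 carbon, 4 nitrogen; no ring), on a saturated chain carbon, four bonds along the chain from an aromatic nitrogen, the same change. Since the earlier step that the two limits leave unreadable from compound 2 to compound 1 gives no direction, the expectation rests on compound 3 and its 100 mg/kg alone. The expected step from compound 3 to compound 4 in this assay is a 1.2-fold higher number from compound 3 to compound 4 (0.08 log units; within the scatter). Compound 4 is therefore expected to give 120 mg/kg, between 50 mg/kg and 300 mg/kg, with a fair chance of a limit instead.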

Compound 4, dose for half-maximal effect: > 100 mg/kg
Compound 4 gave a limit, no number (the forecaster's own chance of this, stated with the estimate: 50%); the middle value is on the limit's open side.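

In this assay compound 4 gives > 100 mg/kg and this is a limit of the assay, not a number. On this core the change gives a number no lower from compound 3 to compound 4 (the limit leaves the size open) and so shows only the direction of the step, not its size. The same change on the core of compound 2 cannot be read, so nothing shows whether the change carries over from one core to the other with a similar size, because the values stop at a limit: the limit of > 100 mg/kg in this assay, at which 3 of the 4 values shown sit.

What the compounds shown leave open is how the series behaves below that limit. As far as these compounds go, whether an amine or a carboxylic acid at the end of the chain, or a longer chain, would give a number in this assay remains unknown.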